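Swapping Benzyl for 4-Methylphenyl on the Amide Nitrogen

This account rests on a few compounds, and the source may have more. Where it says the series, first, only, none or still open, it means among the compounds named here.

Measured so far:
compound 1 `O=C(NCc1ccccc1)c1csc(-c2c[nH]c3ccccc23)n1`: 41400 nM
compound 2 `COc1ccc(NC(=O)c2csc(-c3cn(Cc4ccc(Cl)cc4)c4ccccc34)n2)cc1`: 90900 nM
compound 3 `COc1cc(NC(=O)c2csc(-c3c[nH]c4ccc(Br)cc34)n2)cc(OC)c1OC`: 93000 nM

In a functional assay on HeLa cells (Homo sapiens) for cytotoxicity, read by MTT assay, with a stated time of 48 h, in the presence of a further agent that is not named here (on this read-out higher numbers stand for weaker inhibition and lower numbers for stronger inhibition), compound 1 gives 41400 nM, the lowest of the three numbers; compound 2 with 90900 nM and compound 3 with 93000 nM sit at higher numbers, each beyond the usual scatter, so compound 1 is the strongest inhibitor among them. Compound 4 `Cc1ccc(NC(=O)c2csc(-c3c[nH]c4ccccc34)n2)cc1` has not yet been measured. It differs from compound 1 in one place: 4-methylphenyl in place of benzyl on an amide-type nitrogen. Among the measured compounds shown here, no measured pair isolates this change, and compounds 2 and 3 differ from compound 1 in more than one place, so their higher numbers give only a weak hint. The step from compound 1 to compound 4 in this assay is expected to be modest, a 1.4-fold higher number from compound 1 to compound 4 (0.16 log units; within the scatter), toward a somewhat higher number or none beyond the scatter. Compound 4 is therefore estimated at 60000 nM, within 20000 nM to 180000 nM.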

Compound 4, half-maximal inhibitory concentration: > 100000 nM
Compound 4: only a limit was reported (the forecaster's own chance of this, stated with the estimate: 20%); middle value at least 1.6-fold (0.22 log units) away from the limit.
By their numbers in this assay, from the lowest: compound 1; then compounds 2 and 3 (each within the scatter of the next). At a limit, above all of these: compound 4.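

Among the compounds shown here, this is the first comparison that isolates the group on this amide-type nitrogen, and in this assay the change from benzyl to 4-methylphenyl gives an at least 2.4-fold higher number from compound 1 to compound 4 (0.38 log units; beyond the scatter). Compound 4 reads > 100000 nM, which is a limit of the assay and not a number. Both groups have the same count of heavy atoms and one aromatic ring, so the difference in how those atoms are joined is enough to weaken inhibition here.

On these data alone, what 2-phenylethyl, a longer chain, would do on this nitrogen remains open. So does the effect of an amine on the benzyl ring.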